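The source may report more compounds than this note shows. Statements on the series, on what has been measured and on what is new or still open speak of the compounds shown alone.

Compound 2 `CN1CCN(c2ccc(Nc3ncc4c(n3)N(C3CCCC3)CC(=O)N4C)nc2)CC1` is one of two compounds tested here. Within the data shown here, in a functional assay on HeLa cells (Homo sapiens) for inhibition, read by MTT assay, with a stated time of 48 h (a higher number here means a weaker inhibitor, a lower number a stronger inhibitor), compound 2 gives 13100 nM, the only value on this scale that is a plain number. Among the measured compounds shown here, compound 1 `O=C1CN(C2CCCC2)c2nc(Nc3ccc(N4CCCCC4)cn3)ncc2N1` differs from compound 2 in more than one place, so no single step joins them. In this assay compound 1 reaches only a limit of the assay, > 30000 nM, and so gives no number. Compound 3 `CN1C(=O)CN(C2CCCC2)c2nc(Nc3ccc(N4CCCCC4)cn3)ncc21` is not yet measured; it is made from compound 2 by one change: piperidin-1-yl in place of 4-methylpiperazin-1-yl on an aromatic carbon. For the measured compounds named here, with no measured step of this kind to lean on, only an expectation is possible, and it points toward weaker inhibition rather than stronger, since compound 1, which also carries piperidin-1-yl, sits at the limit of > 30000 nM in this assay, at which 1 of the 2 values shown sits. The step from compound 2 to compound 3 is therefore expected to be a 1.9-fold higher number from compound 2 to compound 3 (0.28 log units; within the scatter), beyond the scatter. Compound 3 is estimated at 25000 nM, with a range from 10000 nM to 60000 nM.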

Compound 3, half-maximal inhibitory concentration: > 30000 nM
Compound 3 was reported as a limit (the forecaster's own chance of this, stated with the estimate: 40%); middle value at least 1.2-fold (0.07 log units) away from the limit.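

In this assay, among these compounds, putting piperidin-1-yl in place of 4-methylpiperazin-1-yl on this aromatic carbon gives the first readable single-change step at this position: an at least 2.2-fold higher number from compound 2 to compound 3 (0.35 log units; beyond the scatter). Among the compounds shown here, compound 1 also carries piperidin-1-yl but differs from compound 2 in more than one place, so only this step ties weaker inhibition to the ring exchange alone. The step that adds a methyl on the amide-type nitrogen between compound 1 and compound 3 cannot be read, and both compounds with piperidin-1-yl stand at a limit of the assay: the limit of > 30000 nM in this assay, at which 2 of the 3 values shown sit.

Going by these compounds, how much weaker piperidin-1-yl really is stays open, since only compound 2 has a plain number. Also open, on these data alone, is how a morpholin-4-yl ring, a piperazine without its methyl, or a simple open-chain amine would behave on this same carbon.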